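Removing the Propyl Branch from the Chain of Compound 2

The source may report more compounds than this note shows. Statements on the series, on what has been measured and on what is new or still open speak of the compounds shown alone.

The measured compounds and their values in an assay on membranes from lung (Cavia porcellus) for binding affinity to cysteinyl leukotriene receptor (Homo sapiens); on this read-out lower numbers stand for stronger inhibition and higher numbers for weaker inhibition:
compound 1, `CC(CCCC(=O)O)c1cccc(OCc2ccc3ccccc3n2)c1`, gives 90 nM;
compound 2, `CCCC(CCC(=O)O)Cc1ccc(OCc2ccc3ccccc3n2)cc1`, gives 21 nM;
compound 3, `CC(Cc1cccc(OCc2ccc3ccccc3n2)c1)CC(C)C(=O)O`, gives 24 nM.

Compound 2 has the lowest number of the three, though its gap to compound 3 is within the scatter; only its gap to compound 1 is beyond it. The unmeasured compound 4, `O=C(O)CCCCc1ccc(OCc2ccc3ccccc3n2)cc1`, differs from compound 2 by hydrogen in place of propyl on a saturated chain carbon bound to two saturated chain carbons. Going by the values given here, the only single-point step available, a 3.8-fold lower number from compound 1 to compound 3 (0.57 log units; beyond the scatter), rearranges and enlarges the chain rather than cutting a branch away, so it bears on the present change only loosely; it shows that alterations of the acid-bearing chain can move the number by a modest amount. Removing the propyl leaves a plainer chain, and a somewhat higher number is expected for compound 4, a 2.9-fold higher number from compound 2 to compound 4 (0.46 log units; beyond the scatter). Compound 4 is therefore estimated at 60 nM in this assay, with a range from 20 nM to 200 nM.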

Compound 4, inhibition constant: 110 nM
Beside the measured number, compound 4's estimate is 1.8-fold (0.26 log units) below it; low and high end bracket the measured number.
By their numbers in this assay, from the lowest: compounds 2 and 3 (each within the scatter of the next); then compounds 1 and 4 (each within the scatter of the next).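

Within this assay, replacing the propyl with hydrogen gives a 5.2-fold higher number from compound 2 to compound 4 (0.72 log units; beyond the scatter), so this saturated chain carbon is a place where the branch matters to the number. The earlier compounds shown here differed by a rearranged and enlarged acid-bearing chain, whereas this pair isolates the loss of a single branch: the step from 1-(2-carboxyethyl)butyl to 3-carboxypropyl on an otherwise unchanged structure. No measurement offered here accounts for the size of this step.

The compounds shown leave open how much of the branch is needed, as a methyl or an ethyl at this carbon could show, and whether a longer chain there would lower the number further. They also leave open whether a hydroxyl or an amine at the same carbon could take the place of the propyl.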